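Swapping the Aryl Group on a Shared Core

The compounds below may be only part of what the source reports. "The series", "measured", "known", "first", "only" and "open" are said of these compounds alone.

Of the compounds shown here, three built on one core have been measured in an in vitro functional assay on HEK285-7 cells for antagonist activity at prostaglandin D2 receptor 2 (Homo sapiens), read by BRET and beta-arrestin recruitment; on this read-out higher numbers stand for weaker inhibition and lower numbers for stronger inhibition. Compound 1 `NS(=O)(=O)c1ccc(-c2nc(C(c3ccc(F)cc3)c3ccc(F)cc3)sc2CC(=O)O)cc1` carries a 4-sulfamoylphenyl group; in this assay compound 1 reaches only a limit of the assay, > 100000 nM, and gives no number. Compound 2 `O=C(O)Cc1sc(C(c2ccc(F)cc2)c2ccc(F)cc2)nc1-c1cc(F)nc(F)c1` carries a 2,6-difluoropyridin-4-yl group, and in this assay compound 2 gives 110 nM. Compound 3 `O=C(O)Cc1sc(C(c2ccc(F)cc2)c2ccc(F)cc2)nc1-c1ccc(Cl)cc1` carries a 4-chlorophenyl group, and in this assay compound 3 gives 180 nM. Of the two numbers, compound 3 has the higher one, but the gap is a 1.6-fold higher number from compound 2 to compound 3 (0.21 log units; within the scatter), so compound 2 and compound 3 cannot be told apart. Leaving the sulfamoyl group behind brings an at least 900-fold lower number from compound 1 to compound 2 (2.95 log units; beyond the scatter) and an at least 550-fold lower number from compound 1 to compound 3 (2.74 log units; beyond the scatter).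

Compound 4 `Cc1cc(-c2nc(C(c3ccc(F)cc3)c3ccc(F)cc3)sc2CC(=O)O)ccn1` has not yet been measured. 2-methylpyridin-4-yl in place of 4-chlorophenyl on an aromatic carbon The measured step most like this one exchanges a pyridinyl for a chlorophenyl, a 1.6-fold higher number from compound 2 to compound 3 (0.21 log units; within the scatter), and stayed within the scatter. The large steps away from compound 1 concern the sulfamoyl group and do not bear on this change. Compound 4 is therefore expected to sit close to compound 3, with a 1.1-fold higher number from compound 3 to compound 4 (0.05 log units; within the scatter) expected to stay within the scatter. The estimate for compound 4 in this assay is 200 nM, with a range from 70 nM to 600 nM.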

Compound 4, half-maximal inhibitory concentration: 53 nM
Beside the measured number, compound 4's estimate is 3.8-fold (0.58 log units) above it; the whole stated range lies above it.
By their numbers in this assay, from the lowest: compound 4; then compounds 2 and 3 (each within the scatter of the next). At a limit, above all of these: compound 1.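

In this assay, the aryl group on the carbon next to the ring nitrogen proves able to shift the number beyond the scatter, with a 3.4-fold lower number from compound 3 to compound 4 (0.53 log units; beyond the scatter), whereas the exchange between compound 2 and compound 3 had stayed within it. The two pyridine-bearing compounds also separate, with a 2.1-fold lower number from compound 2 to compound 4 (0.32 log units; beyond the scatter), so a ring nitrogen in the aryl group does not alone fix the number, and compound 4 now has the lowest number of the four, with its steps to all the others beyond the scatter. The third step, an at least 1800-fold lower number from compound 1 to compound 4 (3.27 log units; beyond the scatter), gives only a minimum size, as compound 1 stands at a limit of the assay: the limit of > 100000 nM in this assay, at which 1 of the 4 values shown sits.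

The 2-methylpyridin-4-yl group differs from 4-chlorophenyl both in its ring nitrogen and in having methyl where the other has chloro, so a plain pyridin-4-yl group and a 4-methylphenyl group would be needed to tell the two changes apart. From the compounds shown here alone, it also remains open whether an ethyl, a methoxy or an amine in place of the methyl would keep the number this low.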